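Open-chain amide in place of the ring at the solubility-tested position

A few compounds are considered here, and "the series" means these few. Any claim that something is new, unique, unknown or untested is made for them only; others in the source may bear on it.

Of the compounds shown here, three sharing one core have been measured in a physicochemical assay for solubility, measured as kinetic solubility, at pH 2; on this read-out higher numbers stand for higher solubility and lower numbers for lower solubility. Compound 1 `CC(C)C(c1ccc(-c2ccc3cccc(F)c3c2)[nH]c1=O)N1CCCCC1=O` gives 23500 nM. Compound 2 `CC(C)C(c1ccc(-c2ccc3cccc(F)c3c2)[nH]c1=O)N1CCN/C1=N\C#N` gives 32500 nM, and compound 3 `CC(C)C(c1noc(=O)[nH]1)c1ccc(-c2ccc3cccc(F)c3c2)[nH]c1=O` gives 23200 nM. All three values lie within the usual scatter of one another: the step of a 1.4-fold higher number from compound 1 to compound 2 (0.14 log units; within the scatter) and the step of a 1.0-fold lower number from compound 1 to compound 3 (0.01 log units; within the scatter) are both small, as is the step of a 1.4-fold lower number from compound 2 to compound 3 (0.15 log units; within the scatter). Within the data shown here, compound 1 therefore stands in the middle of a tight cluster, with no measured step from it that goes beyond the scatter.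

Compound 4 `CC(C)NC(=O)CC(c1ccc(-c2ccc3cccc(F)c3c2)[nH]c1=O)C(C)C` has not yet been measured in this assay. Compared with compound 1 the change is (isopropylcarbamoyl)methyl in place of 2-oxopiperidin-1-yl on a saturated chain carbon bound to an aromatic carbon and a saturated chain carbon. The three measured steps all concern exchanges at this same position, and none of them moved the solubility beyond the scatter, although a six-membered ring, a five-membered non-aromatic ring and a five-membered aromatic ring were compared. On that basis no step beyond the scatter is expected for the exchange to the open-chain group either, in either direction, so the step of a 1.1-fold higher number from compound 1 to compound 4 (0.03 log units; within the scatter) is expected to be small. Compound 4 is estimated at 25000 nM, with a range from 12000 nM to 50000 nM.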

Compound 4, solubility: 24200 nM
Estimate against measurement, compound 4: 1.0-fold (0.01 log units) above; the range from low to high includes it.
By their numbers in this assay, from the lowest: compounds 3, 1, 4 and 2 (each within the scatter of the next).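

In this assay, the exchange to (isopropylcarbamoyl)methyl, which has the same count of heavy atoms as 2-oxopiperidin-1-yl but no ring and one more hydrogen-bond donor, gives a 1.0-fold higher number from compound 1 to compound 4 (0.01 log units; within the scatter), so opening up this group at the saturated chain carbon does not take the number outside the scatter. The open-chain group also lies within the scatter of the two other ring-bearing groups, with a 1.0-fold higher number from compound 3 to compound 4 (0.02 log units; within the scatter) and a 1.3-fold lower number from compound 2 to compound 4 (0.13 log units; within the scatter), which extends the cluster seen among the three ring-bearing compounds to a group with no ring at all. Nothing available bears on why the read-out stays so flat across these four groups.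

Going by these compounds, whether an amine, a carboxylic acid or a chain longer than (isopropylcarbamoyl)methyl at this place would also stay within the scatter remains open. The compounds shown also leave open whether this flat picture holds at any other pH or read-out, and whether it would survive a change elsewhere on the shared core.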